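This account rests on a few compounds, and the source may have more. Where it says the series, first, only, none or still open, it means among the compounds named here.

Measured so far in a functional assay on RAW264.7 cells (Mus musculus) for inhibition; on this read-out higher numbers stand for weaker inhibition and lower numbers for stronger inhibition:
compound 1 `O=C(c1ccc(CN2C(=O)c3ccccc3S2(=O)=O)cc1)N1CCCCC1` gives 50600 nM;
compound 2 `O=C(NCc1ccco1)c1ccc(CN2C(=O)c3ccccc3S2(=O)=O)cc1` gives 24300 nM;
compound 3 `CNC(=O)c1ccc(CN2C(=O)c3ccccc3S2(=O)=O)cc1` gives 37700 nM.

Compound 2 has the lowest number of the three. Its gap to compound 3 is within the scatter, while a 2.1-fold lower number from compound 1 to compound 2 (0.32 log units; beyond the scatter) is beyond it. Compound 4 `COC(=O)N(Cc1ccco1)C(=O)c1ccc(CN2C(=O)c3ccccc3S2(=O)=O)cc1` differs from compound 2 by methoxycarbonyl in place of hydrogen on an amide-type nitrogen. Going by the values given here, no measured step alters a substituent on this amide-type nitrogen; the closest point of comparison is a 1.3-fold lower number from compound 1 to compound 3 (0.13 log units; within the scatter), where a secondary and a tertiary amide gave numbers within the scatter of each other. Among the compounds with values here, with no step bearing directly on the change, compound 4 is expected to land close to compound 2, with an estimated 1.2-fold higher number from compound 2 to compound 4 (0.09 log units; within the scatter), so that compound 4 is estimated at 30000 nM (range 12000 nM to 75000 nM).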

Compound 4, half-maximal inhibitory concentration: 76000 nM
Beside the measured number, compound 4's estimate is 2.5-fold (0.40 log units) below it, and the stated range ends below it.
By their numbers in this assay, from the lowest: compounds 2, 3, 1 and 4 (each within the scatter of the next, the first and the last beyond it).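

In this assay, going by these compounds alone, methoxycarbonyl in place of the amide hydrogen gives a 3.1-fold higher number from compound 2 to compound 4 (0.50 log units; beyond the scatter) and this is the first measured change on this amide-type nitrogen. The nitrogen is therefore not indifferent to substitution, since this replacement moves the number beyond the scatter towards weaker inhibition. No measurement on hand accounts for this step. What a methyl or an acetyl group on this nitrogen would give remains open, so the compounds shown do not separate losing the amide hydrogen from adding methoxycarbonyl.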